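Working notes on the series: compound 2 to compound 3

A few compounds are considered here, and "the series" means these few. Any claim that something is new, unique, unknown or untested is made for them only; others in the source may bear on it.

Compound 1 `CCN(CC)c1cc2[nH]c(C3CCCCC3)nc2cc1NC(=O)c1ccc(N(C)C)cc1`: "not determined" (no result reported)
Compound 2 `CCCC(C)OC(=O)Nc1cc2nc(C3CCCCC3)[nH]c2cc1N(CC)CC`: > 100 ug/mL

In an ADME assay on Vero cells (Chlorocebus sabaeus) for cytotoxicity, read by resazurin assay, with a stated time of 3 days (a higher number here means a weaker inhibitor, a lower number a stronger inhibitor), compound 1 is recorded as "not determined" (no result reported). For compound 2 the value in this assay is a limit of the assay, > 100 ug/mL, so only a bound is known. Compound 2 thus stands at the limit of > 100 ug/mL in this assay, at which 1 of the 2 values shown sits, and the set holds no single number against which a step could be sized. Compound 3 `CCN(CC)c1cc2[nH]c(C3CCCCC3)nc2cc1NC(=O)NCc1ccccc1` has not yet been measured in this assay. It differs from compound 2 by benzylamino in place of 1-methylbutoxy on a carbonyl carbon. For the measured compounds named here, no measured step exists to calibrate this change. For compound 3 in this assay the expected step is none beyond the scatter, a number no higher from compound 2 to compound 3 (the limit leaves the size open), most likely again returned as a limit. Compound 3 is therefore estimated at 100 ug/mL, within 40 ug/mL to 250 ug/mL.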

Compound 3, half-maximal inhibitory concentration: > 100 ug/mL
Compound 3: only a limit was reported; the forecaster's own chance of this, stated with the estimate: 65%; the middle value lies on the limit itself.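

In this assay no step can be read between compound 2 and compound 3, since each is reported only as a limit: the limit of > 100 ug/mL in this assay, at which 2 of the 3 values shown sit.

The compounds shown leave open whether benzylamino in place of 1-methylbutoxy on a carbonyl carbon shifts the value in this assay at all.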